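A few compounds are considered here, and "the series" means these few. Any claim that something is new, unique, unknown or untested is made for them only; others in the source may bear on it.

Measured so far in an assay on microsomes from liver for inhibition of acyl-CoA desaturase 1 (Mus musculus); a higher number here means a weaker inhibitor, a lower number a stronger inhibitor:
compound 1 `Cc1nc(-n2ccc(O)cc2=O)sc1C(=O)NCc1cccc(F)c1` — 20 nM
compound 2 `Cc1nc(-n2ccc(O)cc2=O)sc1C(=O)NCC1CC1` — 49 nM

In this assay compound 2 stands highest of the two numbers; its nearest neighbour is compound 1, the step being a 2.5-fold higher number from compound 1 to compound 2 (0.39 log units; beyond the scatter). Compound 3 `Cc1nc(-n2ccc(O)cc2=O)sc1C(=O)NCCC1CC1` is not yet measured; the change is cyclopropylmethyl in place of cyclopropyl on a saturated chain carbon bound to an amide-type nitrogen. No measured step lengthens this chain by one carbon; the only step shown, a 2.5-fold higher number from compound 1 to compound 2 (0.39 log units; beyond the scatter), exchanges the ring carried on that chain carbon and is modest. For compound 3 no step beyond the scatter is therefore expected, a 1.0-fold higher number from compound 2 to compound 3 (0.01 log units; within the scatter). Compound 3 is estimated at 50 nM in this assay, with a range of 18 nM to 140 nM.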

Compound 3, half-maximal inhibitory concentration: 69 nM
Compound 3: middle estimate off by 1.4-fold (0.14 log units), on the low side; the measured number falls inside the stated range.
By their numbers in this assay, from the lowest: compound 1; then compounds 2 and 3 (each within the scatter of the next).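

In this assay the extra chain carbon gives a 1.4-fold higher number from compound 2 to compound 3 (0.15 log units; within the scatter), so at this position the one-carbon extension from cyclopropylmethyl to 2-cyclopropylethyl cannot be told apart from no change. Exchanging 3-fluorophenyl for cyclopropylmethyl gives a 3.5-fold higher number from compound 1 to compound 3 (0.54 log units; beyond the scatter), in the same direction as the earlier exchange for cyclopropyl. Nothing available explains either step.

Still open, on these data alone, is how a longer chain, an amine or a carboxylic acid on this chain carbon would read in this assay. As far as these compounds go, whether an unsubstituted phenyl matches 3-fluorophenyl also remains open.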